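This account rests on a few compounds, and the source may have more. Where it says the series, first, only, none or still open, it means among the compounds named here.

Compound 2 `Fc1cccc(-c2nc(Nc3ccccc3F)c3cc(F)ccc3n2)c1` was tested in a functional assay on HL-60 cells (Homo sapiens) for cytotoxicity, read by MTT assay, with a stated time of 48 h; a lower number here means a stronger inhibitor, a higher number a weaker inhibitor. In this assay compound 2 gives only a limit, > 50000 nM, so no exact number is known for it; one of the two values shown sits at this limit (the limit of > 50000 nM in this assay, at which 1 of the 2 values shown sits). Compound 1 `COc1ccc(Nc2nc(-c3cccc(F)c3)nc3ccc(F)cc23)cc1` gives 38600 nM in this assay. Within the data shown here, the one measured step runs an at least 1.2-fold higher number from compound 1 to compound 2 (0.11 log units; that floor lies within the scatter), a change of 2-fluorophenyl in place of 4-methoxyphenyl on a nitrogen on an aromatic ring. Compound 3 `Nc1ccccc1Nc1nc(-c2cccc(F)c2)nc2ccc(F)cc12` differs from compound 2 in another way: amino in place of fluoro on an aromatic carbon. Among the measured compounds shown here, no measured step shows this exchange, so the single step seen bears on it only by fixing where compound 2 stands, not by showing the direction of this change. The number for compound 3 is therefore expected to stay close to that of compound 2, with a step of an at least 1.1-fold lower number from compound 2 to compound 3 (0.04 log units; that floor lies within the scatter) not expected to go beyond the scatter. The estimate for compound 3 is 45000 nM, with a range from 15000 nM to 150000 nM.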

Compound 3, half-maximal inhibitory concentration: 41300 nM
The estimate for compound 3 lay 1.1-fold (0.04 log units) above the measured number, and the stated range covers the measured number.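

With compound 3, the (2-aminophenyl)amino group has an exact number in this assay, which the (2-fluorophenyl)amino group of compound 2 lacks: the limit of > 50000 nM in this assay, at which 1 of the 3 values shown sits. Amino in place of fluoro on an aromatic carbon gives an at least 1.2-fold lower number from compound 2 to compound 3 (0.08 log units; that floor lies within the scatter), and because compound 2 has only a limit, this is a floor and the true size of the step remains unknown: the limit of > 50000 nM in this assay, at which 1 of the 3 values shown sits. Exchanging 4-methoxyphenyl for 2-aminophenyl gives a 1.1-fold higher number from compound 1 to compound 3 (0.03 log units; within the scatter), so these two groups cannot be told apart in this assay.

On these data alone, it remains open whether another group in this place, such as a hydroxyl, a carboxylic acid or a longer chain like aminomethyl, would move the number beyond the scatter. The rest of the core is the same in all three compounds, so these results say nothing about changes there.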